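The source may report more compounds than this note shows. Statements on the series, on what has been measured and on what is new or still open speak of the compounds shown alone.

Measured so far:
compound 1 `COc1cc(-c2cc(/C=C/C(=O)c3ccc(N)cc3)[nH]n2)cc(OC)c1OC`, which in a functional assay on CCRF-CEM cells (Homo sapiens) for cytotoxicity, read by sulforhodamine B assay, with a stated time of 48 h, tested at 0.1 uM (a higher number here means a weaker effect of the compound at the concentration tested, a lower number a stronger effect), gives 91%
compound 2 `COc1ccc(C(=O)/C=C/c2cc(-c3cc(OC)c(OC)c(OC)c3)n[nH]2)cc1`, which in this assay gives 98%

Among the compounds with values here, compound 2 stands at the highest of these two numbers, but its only neighbour is compound 1, and the step of a number 7 percentage points higher from compound 1 to compound 2 (within the scatter) lies within the scatter, so the two cannot be ranked. Compound 3 `COc1cc(-c2cc(/C=C/C(=O)c3ccc(F)c(F)c3)[nH]n2)cc(OC)c1OC` differs from compound 2 in one place: 3,4-difluorophenyl in place of 4-methoxyphenyl on a carbonyl carbon. Within the data shown here, the one measured step, a number 7 percentage points higher from compound 1 to compound 2 (within the scatter), also swapped a group on that aryl ring and stayed within the scatter, so the step of a number 4 percentage points lower from compound 2 to compound 3 (within the scatter) is expected to stay within the scatter as well. Compound 3 is therefore estimated at 94%, in the range 80% to 102%.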

Compound 3, a percentage reported as activity, at one concentration (the size of the read-out at that concentration, not a potency): 96%
Estimate against measurement, compound 3: 2 percentage points below, and the stated range covers the measured number.
By their numbers in this assay, from the lowest: compounds 1, 3 and 2 (each within the scatter of the next).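

Swapping the group on the carbonyl carbon for 3,4-difluorophenyl gives a number 2 percentage points lower from compound 2 to compound 3 (within the scatter) and a number 5 percentage points higher from compound 1 to compound 3 (within the scatter) in this assay. Three different aryl groups at this place, including one with two fluorines and no hydrogen-bond acceptor, therefore cannot be ranked, so this change shows no effect that the assay can resolve. Nothing available explains why these numbers stay so close.

From the compounds shown here alone, whether a carboxylic acid or a longer chain at this place would move the number beyond the scatter remains open. So does the behaviour of these compounds at other concentrations.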